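Cyclohexylamine for sec-butylamine in the dienone series

The source may report more compounds than this note shows. Statements on the series, on what has been measured and on what is new or still open speak of the compounds shown alone.

Compound 3 `CCC(C)NC(=C\C(=O)/C=C/c1ccc(OC(C)=O)c(OC)c1)/C=C/c1ccc(OC(C)=O)c(OC)c1` carries two acetylated, methoxylated aryl ends and a sec-butyl group on the amine nitrogen. In a functional assay on Caco-2 cells (Homo sapiens) for inhibition, read by MTT assay, with a stated time of 72 h (on this read-out higher numbers stand for weaker inhibition and lower numbers for stronger inhibition), compound 3 gives only a limit, > 25000 nM. Compound 1 `COc1cc(/C=C/C(=O)/C=C(/C=C/c2ccc(OC(C)=O)c(OC)c2)NC2CCCCC2)ccc1OC(C)=O` keeps the same aryl ends; in this assay compound 1 gives 9700 nM. The step of an at least 2.5-fold lower number from compound 3 to compound 1 (0.41 log units; beyond the scatter) is the change (cyclohexyl in place of sec-butyl on an amine nitrogen), read against (the limit of > 25000 nM in this assay, at which 1 of the 3 values shown sits). Compound 2 `CCC(C)NC(=C\C(=O)/C=C/c1ccc(O)cc1)/C=C/c1ccc(O)cc1` has free phenols and the sec-butyl group; in this assay compound 2 gives 9400 nM, close to compound 1 within the scatter. The difference between the cores of compound 2 and compound 3 is not broken down here. Compound 4 `O=C(/C=C(/C=C/c1ccc(O)cc1)NC1CCCCC1)/C=C/c1ccc(O)cc1` is compound 2 with the same change, (cyclohexyl in place of sec-butyl on an amine nitrogen). A step of about a 2.1-fold lower number from compound 2 to compound 4 (0.32 log units; beyond the scatter) is expected, resting on an at least 2.5-fold lower number from compound 3 to compound 1 (0.41 log units; beyond the scatter), which itself starts from a limit and so sets only a floor. Compound 4 is estimated at 4500 nM, between 1800 nM and 11000 nM.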

Compound 4, half-maximal inhibitory concentration: 7800 nM
Compound 4: middle estimate off by 1.7-fold (0.24 log units), on the low side; low and high end bracket the measured number.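

On the core with free phenols, cyclohexyl in place of sec-butyl on an amine nitrogen gives a 1.2-fold lower number from compound 2 to compound 4 (0.08 log units; within the scatter) in this assay, so on this core the change shows no step beyond the scatter. Set beside the step on the core with acetylated, methoxylated aryl ends, the two readings are: the same change on two cores in this assay, an at least 2.5-fold lower number (0.41 log units; beyond the scatter) from compound 3 to compound 1 and a 1.2-fold lower number (0.08 log units; within the scatter) from compound 2 to compound 4; the limit leaves it open whether they differ
The data therefore show neither that the change carries over unchanged nor that its size depends on the core, and the earlier step starts from a value that is a limit and not a number: the limit of > 25000 nM in this assay, at which 1 of the 4 values shown sits.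

Still open, on these data alone, is how other groups on the amine nitrogen, such as cyclopentyl, benzyl or a longer chain, would read on either core.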